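This account rests on a few compounds, and the source may have more. Where it says the series, first, only, none or still open, it means among the compounds named here.

Three compounds sharing one core were tested in a functional assay on HL-60 cells (Homo sapiens) for inhibition, read by MTT assay, with a stated time of 72 h; on this read-out lower numbers stand for stronger inhibition and higher numbers for weaker inhibition. Compound 1 `Cc1nc(-c2ccccc2)c(C(=O)N2CCN(c3ccccc3Cl)CC2)o1` gives 124 nM, compound 2 `COc1cc(OC)cc(N2CCN(C(=O)c3onc(C)c3-c3ccc(-c4ccco4)cc3)CC2)c1` gives 191 nM, and compound 3 `COc1ccc(Cl)cc1N1CCN(C(=O)c2oc(C)nc2-c2ccccc2F)CC1` gives 153 nM. Compound 1 has the lowest of the three numbers, yet compound 3 and compound 2 both lie within the scatter of it, so no order among them can be claimed.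

Compound 4 `CCOc1cccc(N2CCN(C(=O)c3oc(C)nc3-c3ccccc3)CC2)c1` has not yet been measured. It differs from compound 1 in one place: 3-ethoxyphenyl in place of 2-chlorophenyl on an amine nitrogen in a ring. Among the compounds with values here, no measured pair shows this exact change, so only the closeness of the three known numbers, obtained with different groups on the amine nitrogen in a ring, can guide an expectation. The step of a 1.5-fold higher number from compound 1 to compound 4 (0.16 log units; within the scatter) is therefore expected to be small, none beyond the scatter. Compound 4 is expected to give 180 nM, with a range from 80 nM to 400 nM.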

Compound 4, half-maximal inhibitory concentration: 151 nM
Compound 4: the middle estimate sits 1.2-fold (0.08 log units) above what was measured; low and high end bracket the measured number.
By their numbers in this assay, from the lowest: compounds 1, 4, 3 and 2 (each within the scatter of the next).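

In this assay, 3-ethoxyphenyl in place of 2-chlorophenyl on the amine nitrogen in a ring gives a 1.2-fold higher number from compound 1 to compound 4 (0.09 log units; within the scatter). Within the data shown here, this is the first direct comparison at this position, and the two groups cannot be told apart here, although the entering group has more heavy atoms and a hydrogen-bond acceptor. No measurement is available to explain this result. The compounds shown leave open whether this position accepts anything other than a substituted phenyl ring, such as a plain methyl, an aminoethyl chain or a carboxylic acid.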